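The source may hold more compounds than are shown below. What is called first, only, known or untested is meant among the compounds shown, and "the series" means these compounds.

Measured so far in an assay on isolated protein for inhibition of sphingomyelin phosphodiesterase (Homo sapiens), read by fluorescence, with a stated time of 30 min; a higher number here means a weaker inhibitor, a lower number a stronger inhibitor:
compound 1 `O=C(NO)c1cccc(OCc2ccc(-c3noc(-c4ccc(Br)cc4)n3)cc2)c1` — a limit of > 100000 nM
compound 2 `O=C(NO)c1cccc(OCc2ccc(-c3noc(-c4ccccc4F)n3)cc2)c1` — a limit of > 100000 nM
compound 3 `O=C(NO)c1cccc(OCc2ccc(-c3noc(-c4cccc(F)c4)n3)cc2)c1` — a limit of > 100000 nM

Compound 1 stands only as a limit in this assay, not as a number. Nothing places it relative to compound 2 or compound 3, because of the limit of > 100000 nM in this assay, at which 3 of the 3 values shown sit. The three pairwise comparisons accordingly carry no readable size: a step that the two limits leave unreadable from compound 1 to compound 2; a step that the two limits leave unreadable from compound 1 to compound 3; a step that the two limits leave unreadable from compound 2 to compound 3. All three of these steps concern the halogenated phenyl ring at the far end of the shared core, and none of them reads.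

Compound 4 `COc1ccc(C(=O)NO)cc1OCc1ccc(-c2noc(-c3ccc(Br)cc3)n2)cc1` is the next compound and has not yet been measured in this assay. It differs from compound 1 by methoxy in place of hydrogen on an aromatic carbon. Among the measured compounds shown here, no measured step touches this part of the structure, and the steps that do exist give no size in either direction, so the only footing is that every value so far sits at the limit.

On that footing the expected step is a step that the limit leaves unreadable from compound 1 to compound 4, which is to say no change that the assay could read, and most probably a further limit. Compound 4 is estimated at 150000 nM, with a range from 40000 nM to 1000000 nM.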

Compound 4, half-maximal inhibitory concentration: > 100000 nM
Compound 4: a limit, no number (the forecaster's own chance of this, stated with the estimate: 85%); the middle value lies beyond the limit too.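

The step between compound 1 and compound 4 cannot be read, because neither compound has a number in this assay, only a limit: the limit of > 100000 nM in this assay, at which 4 of the 4 values shown sit. The compounds shown leave open whether any change to the shared core, at the halogenated phenyl ring or through methoxy in place of hydrogen, gives a readable value in this assay.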